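Isopropyl on the chain of the acid compound 3

The source may report more compounds than this note shows. Statements on the series, on what has been measured and on what is new or still open speak of the compounds shown alone.

Compound 1 `CCn1c(C(=O)NCCC(=O)OC)ccc1C(CC)(CC)c1ccc(C#CC(O)(CC)CC)c(C)c1` gives > 50000 nM (a limit)
Compound 2 `C#CCCOC(=O)c1ccc(C(CC)(CC)c2ccc(C#CC(O)(CC)CC)c(C)c2)n1CC` gives > 50000 nM (a limit)
Compound 3 `CCn1c(C(=O)NCC(=O)O)ccc1C(CC)(CC)c1ccc(C#CC(O)(CC)CC)c(C)c1` gives 5140 nM (a number)

In a functional assay on MCF7 cells (Homo sapiens) for antiproliferative activity, read by MTT assay, with a stated time of 72 h (on this read-out higher numbers stand for weaker inhibition and lower numbers for stronger inhibition), compound 3 gives 5140 nM and is the only one of the three with a true number. Compound 1 and compound 2 both rest at the limit of > 50000 nM in this assay, at which 2 of the 3 values shown sit, and so carry only a limit.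

Compound 4 `CCn1c(C(=O)N[C@H](C(=O)O)C(C)C)ccc1C(CC)(CC)c1ccc(C#CC(O)(CC)CC)c(C)c1` differs from compound 3 by isopropyl in place of hydrogen on a saturated chain carbon bound to an amide-type nitrogen and a carbonyl carbon and so turns carboxymethyl into 1-carboxy-2-methylpropyl, while the carboxy group stays.

Two measured steps reach this part of the molecule: an at least 9.7-fold lower number from compound 1 to compound 3 (0.98 log units; beyond the scatter) and also an at least 9.7-fold lower number from compound 2 to compound 3 (0.98 log units; beyond the scatter) and both lie beyond the scatter. Both end at the free carboxy compound, but neither replaces a hydrogen with isopropyl, so they give no size for this change. For the measured compounds named here, they suggest only that compound 4, which shares the carboxy group of compound 3 (5140 nM), can be expected to give a number rather than a limit.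

In this assay the expected change is a 1.2-fold higher number from compound 3 to compound 4 (0.07 log units; within the scatter) and it is not expected to leave the scatter. For compound 4 the estimate is 6000 nM with 1500 nM to 30000 nM as the expected range.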

Compound 4, half-maximal inhibitory concentration: 13000 nM
Estimate against measurement, compound 4: 2.2-fold (0.34 log units) below, within the range that was stated.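

In this assay, the saturated chain carbon bound to an amide-type nitrogen and a carbonyl carbon now has a measured step of its own: a 2.5-fold higher number from compound 3 to compound 4 (0.40 log units; beyond the scatter). Isopropyl in place of hydrogen at this carbon therefore moves the number beyond the scatter, towards weaker inhibition, yet the carboxy group still gives a true number rather than a limit. Compound 4 also stands clear of the two ester compounds, with an at least 3.8-fold lower number from compound 2 to compound 4 (0.58 log units; beyond the scatter) and an at least 3.8-fold lower number from compound 1 to compound 4 (0.58 log units; beyond the scatter), and both steps start from a limit, so their full size cannot be read: the limit of > 50000 nM in this assay, at which 2 of the 4 values shown sit.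

Isopropyl is the only group other than hydrogen shown at this carbon, so it stays open whether methyl or benzyl in its place would give a smaller or a larger step. Also open, as far as these compounds go, is what the opposite configuration at this carbon would give, and whether the same isopropyl group would read the same way with a primary amide in place of the carboxy group.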